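Stereochemistry inversion on the cyclopropyl amide

A few compounds are considered here, and "the series" means these few. Any claim that something is new, unique, unknown or untested is made for them only; others in the source may bear on it.

Measured so far in an assay on SH-EP1 cells for agonist activity at Neuronal acetylcholine receptor; alpha4/beta2 (Homo sapiens), read by FLIPR and calcium flux; on this read-out lower numbers stand for an effect already at smaller amounts and higher numbers for an effect only at larger amounts of compound:
Compound 1, `CCC(=O)N1CC2CC(C1)N2`, gives 5900 nM.
Compound 2, `C[C@H]1C[C@H]1C(=O)N1CC2CC(C1)N2`, gives 5800 nM.

Compound 2 stands at the lowest of the two numbers, but its nearest neighbour is compound 1, and the two values lie within the scatter of each other, so no order between them can be read. Among the measured compounds shown here, the only measured step is a 1.0-fold lower number from compound 1 to compound 2 (0.01 log units; within the scatter), which shows that replacing the chain on the carbonyl carbon by the substituted small ring left the read-out unchanged.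

Compound 3, `C[C@@H]1C[C@H]1C(=O)N1CC2CC(C1)N2`, differs from compound 2 as follows: the two compounds have the same atoms and bonds; at least one stereo element is drawn with a configuration in one of them and without one in the other: 1 of 4 stereo elements differ; a stereocentre at a saturated ring carbon is drawn S in compound 2 and R in compound 3. For the measured compounds named here, no measured pair bears directly on a change of configuration at that carbon; the one step available concerns the group itself, not its stereochemistry, and it was flat. With nothing pointing in either direction, the expected step in this assay is none beyond the scatter. Compound 3 is therefore estimated at 6000 nM, with a range from 2000 nM to 18000 nM. The estimate amounts to an expected 1.0-fold higher number from compound 2 to compound 3 (0.01 log units; within the scatter), a step anticipated to stay within the usual scatter.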

Compound 3, half-maximal effective concentration: 2900 nM
Estimate against measurement, compound 3: 2.1-fold (0.32 log units) above; measured number inside the range.
By their numbers in this assay, from the lowest: compounds 3, 2 and 1 (each within the scatter of the next, the first and the last beyond it).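

The configuration at this saturated ring carbon now has its first reading in this assay: exchanging S for R gives a 2.0-fold lower number from compound 2 to compound 3 (0.30 log units; within the scatter), so the pair alone sets no order between the two forms. Among the compounds shown here, the comparison with the open chain gives a different picture from the earlier flat step, since 2-methylcyclopropyl in place of ethyl on the carbonyl carbon, when drawn with R at that ring carbon, gives a 2.0-fold lower number from compound 1 to compound 3 (0.31 log units; beyond the scatter), the only step so far that lies beyond the scatter, and a modest one. The stereo comparison also carries a caution about how firmly the two forms can be told apart: the fact that one of compounds 2 and 3 is drawn with a defined configuration and the other without, at the place where they differ

Whether the change of group or the configuration at the ring carbon accounts for that modest step remains open, as the step between the two stereo forms does not settle it. Also open, as far as these compounds go, is how the number would respond to an unsubstituted cyclopropyl, a longer chain or a phenyl ring on the carbonyl carbon, and whether any of these would carry the read-out further from the values seen here.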